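Moving One Hydroxy Group on the Benzyl Side Chain

This account rests on a few compounds, and the source may have more. Where it says the series, first, only, none or still open, it means among the compounds named here.

Compound 1 `COc1ccc(Cc2cn(C3CC3)c3c(F)c(-c4cc(C)nc(C)c4)c(F)cc3c2=O)cc1`: 21000 nM
Compound 2 `COc1ccccc1Cc1cn(C2CC2)c2c(F)c(-c3cc(C)nc(C)c3)c(F)cc2c1=O`: 37000 nM
Compound 3 `Cc1cc(-c2c(F)cc3c(=O)c(Cc4cccc(O)c4O)cn(C4CC4)c3c2F)cc(C)n1`: 880 nM

These values come from a functional assay on P388 cells (Mus musculus) for cytotoxicity; a higher number here means a weaker inhibitor, a lower number a stronger inhibitor. The three compounds share one core and differ only in the aromatic group on a saturated chain carbon bound to an aromatic carbon. Compound 3 has the lowest number and is the strongest inhibitor of the three: the record shows a 24-fold lower number from compound 1 to compound 3 (1.38 log units; beyond the scatter) and a 42-fold lower number from compound 2 to compound 3 (1.62 log units; beyond the scatter).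

Compound 4 `Cc1cc(-c2c(F)cc3c(=O)c(Cc4ccc(O)cc4O)cn(C4CC4)c3c2F)cc(C)n1` alters that same group: 2,4-dihydroxyphenyl in place of 2,3-dihydroxyphenyl on a saturated chain carbon bound to an aromatic carbon. Here 2,4-dihydroxyphenyl takes the place of 2,3-dihydroxyphenyl, so the group keeps its make-up and only its arrangement changes. Among the compounds with values here, the closest precedent is a 1.8-fold higher number from compound 1 to compound 2 (0.25 log units; within the scatter), where 2-methoxyphenyl replaced 4-methoxyphenyl, a similar rearrangement with little effect. That is a single pair, however, and it involves methoxy groups. Within the data shown here, the two large steps show that the dihydroxy group matters, but no measured compound shows whether the new arrangement keeps its gain.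

A modest step is therefore expected in this assay, more likely toward a higher number, since compound 3, at 880 nM, already sits lowest. The estimated change is a 2.0-fold higher number from compound 3 to compound 4 (0.31 log units; beyond the scatter). The expected value for compound 4 is 1800 nM, within an estimated range of 350 nM to 10000 nM.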

Compound 4, half-maximal inhibitory concentration: 210 nM
Estimate against measurement, compound 4: 8.6-fold (0.93 log units) above, and the stated range ends above it.
By their numbers in this assay, from the lowest: compound 4; then compound 3; then compounds 1 and 2 (each within the scatter of the next).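

In this assay, the arrangement of the hydroxy groups matters in its own right: the group entering and the group leaving have the same atoms, joined differently, yet the change to 2,4-dihydroxyphenyl gives a 4.2-fold lower number from compound 3 to compound 4 (0.62 log units; beyond the scatter). The distance from the methoxy compounds also widens, with a 180-fold lower number from compound 2 to compound 4 (2.25 log units; beyond the scatter) and a 100-fold lower number from compound 1 to compound 4 (2.00 log units; beyond the scatter), which makes compound 4 the strongest inhibitor of the four. Moving a methoxy group gave only a 1.8-fold higher number from compound 1 to compound 2 (0.25 log units; within the scatter), which is within the scatter, whereas rearranging the two hydroxy groups gives a step beyond it, so at this position on a saturated chain carbon bound to an aromatic carbon, the methoxy pair did not predict what the dihydroxy pair would do.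

Nothing among the data shown gives a reason for the difference between the two dihydroxy arrangements. Going by these compounds, it also remains open whether a benzyl group carrying a single hydroxy group, or an amine or a carboxylic acid in place of the hydroxy groups, would keep a number as low as that of compound 4.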